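Fluoro-to-methoxy swap on the benzyl ring, compound 3

This account rests on a few compounds, and the source may have more. Where it says the series, first, only, none or still open, it means among the compounds named here.

Measured so far:
compound 1, `CC(C)NC(=O)N1CCN(C(=S)SCc2cn(Cc3ccc(F)cc3)nn2)CC1`: 1660 nM
compound 2, `CCN(C)C(=O)N1CCN(C(=S)SCc2cn(Cc3ccc(F)cc3)nn2)CC1`: 2150 nM

Both were read in a functional assay on MCF7 cells (Homo sapiens) for cytotoxicity, read by MTT assay, with a stated time of 72 h; on this read-out lower numbers stand for stronger inhibition and higher numbers for weaker inhibition. Compound 2 holds the highest of the two numbers, its nearest neighbour being compound 1, and the step of a 1.3-fold higher number from compound 1 to compound 2 (0.11 log units; within the scatter) lies within the scatter.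

Compound 3, `CCN(C)C(=O)N1CCN(C(=S)SCc2cn(Cc3ccc(OC)cc3)nn2)CC1`, differs from compound 2 by methoxy in place of fluoro on an aromatic carbon. Among the compounds with values here, the only measured step alters the group on the carbonyl carbon, not the benzyl ring, so no measured step bears on this change. Nothing beyond the scatter is therefore expected.

Compound 3 is estimated at 2300 nM, within 900 nM to 5500 nM. Compound 3 is thus expected to show a 1.1-fold higher number from compound 2 to compound 3 (0.03 log units; within the scatter).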

Compound 3, half-maximal inhibitory concentration: 21400 nM
Compound 3: middle estimate off by 9.3-fold (0.97 log units), on the low side, outside the stated range (above it).
By their numbers in this assay, from the lowest: compounds 1 and 2 (each within the scatter of the next); then compound 3.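

Within the data shown here, the benzyl ring substituent is the one place so far where a single change moves the number beyond the scatter in (this assay): methoxy in place of fluoro, para to a large group, gives (a 10-fold higher number from compound 2 to compound 3 (1.00 log units; beyond the scatter)). 4-Fluorobenzyl and 4-methoxybenzyl are therefore not interchangeable here, whereas the change on the carbonyl carbon (a 1.3-fold higher number from compound 1 to compound 2 (0.11 log units; within the scatter)) stays within the scatter. No available evidence accounts for this step.

On these data alone, whether a chloro or methyl group at this place, or an unsubstituted benzyl group, would stay close to compound 2 remains open. Also open, as far as these compounds go, is whether the same swap has a similar effect with isopropylamino on the carbonyl carbon.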